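This account rests on a few compounds, and the source may have more. Where it says the series, first, only, none or still open, it means among the compounds named here.

The measured compounds in a functional assay on the whole organism with Rattus norvegicus as the target; on this read-out lower numbers stand for an effect already at smaller amounts and higher numbers for an effect only at larger amounts of compound:
Compound 1, `COC(=O)CC/C=C\CC[C@H]1C(=O)C[C@@H](O)[C@@H]1/C=C/C[C@@](C)(O)/C=C/C1=CCCC1`, reached only a limit of the assay, > 3.16 mg/kg.
Compound 2, `COC(=O)CC/C=C\CC[C@H]1C(=O)C[C@@H](O)[C@@H]1/C=C/CC(C)(O)CCC1CCCC1`, gave 1.31 mg/kg.
Compound 3, `COC(=O)CC/C=C\CC[C@H]1C(=O)C[C@@H](O)[C@@H]1/C=C/CC(C)(O)CCC1CC1`, gave 0.273 mg/kg.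

Compound 3 holds the lowest of the two numbers. Its nearest neighbour is compound 2, and the step between them, a 4.8-fold lower number from compound 2 to compound 3 (0.68 log units; beyond the scatter), lies beyond the scatter. Compound 1 stands apart, since it gave only a limit, (the limit of > 3.16 mg/kg in this assay, at which 1 of the 3 values shown sits).

Compound 4, `COC(=O)CC/C=C\CC[C@H]1C(=O)C[C@@H](O)[C@@H]1/C=C/CC(C)(O)CCC1CCC1`, differs from compound 3 in one place: cyclobutyl in place of cyclopropyl on a saturated chain carbon, three bonds along the chain from an oxygen on a saturated carbon. The measured step that bears most directly on this change is a 4.8-fold lower number from compound 2 to compound 3 (0.68 log units; beyond the scatter), in which cyclopropyl took the place of cyclopentyl at the same position. The larger step of an at least 11-fold lower number from compound 1 to compound 3 (1.06 log units; beyond the scatter) also ends at compound 3, but it carries a further change in the chain and is less telling. Since cyclobutyl stands between the three-membered ring of compound 3 and the five-membered ring of compound 2, the number for compound 4 is expected to fall between those two compounds, nearer the smaller ring. The expected step is therefore a 1.8-fold higher number from compound 3 to compound 4 (0.26 log units; within the scatter), a modest rise, probably beyond the scatter. For compound 4 a value of 0.5 mg/kg is estimated, with a range from 0.2 mg/kg to 1.3 mg/kg.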

Compound 4, dose for half-maximal effect: 0.316 mg/kg
Estimate against measurement, compound 4: 1.6-fold (0.20 log units) above, within the range that was stated.
By their numbers in this assay, from the lowest: compounds 3 and 4 (each within the scatter of the next); then compound 2. At a limit, above all of these: compound 1.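

In this assay, cyclobutyl and cyclopropyl cannot be told apart on a saturated chain carbon, three bonds along the chain from an oxygen on a saturated carbon, with a 1.2-fold higher number from compound 3 to compound 4 (0.06 log units; within the scatter). The earlier compounds set only cyclopropyl against cyclopentyl, whereas the new result shows that cyclobutyl also gives a clearly lower number than cyclopentyl, with a 4.1-fold lower number from compound 2 to compound 4 (0.62 log units; beyond the scatter), so among these three rings the higher number belongs to cyclopentyl alone. The widest step, an at least 10-fold lower number from compound 1 to compound 4 (1.00 log units; beyond the scatter), starts from a value that is only a limit of the assay and also carries a further change in the chain: the limit of > 3.16 mg/kg in this assay, at which 1 of the 4 values shown sits.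

The compounds shown leave open whether a group without a ring at this position, such as a plain butyl chain, would match cyclopropyl and cyclobutyl, and whether a cyclohexyl or phenyl ring would give a number nearer that of cyclopentyl. They also do not say how a ring carrying an oxygen, such as tetrahydrofuranyl, or a basic amine such as piperidinyl would read in this assay, and they offer no measurement that explains why the rings differ.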